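This account rests on a few compounds, and the source may have more. Where it says the series, first, only, none or still open, it means among the compounds named here.

Of the compounds shown here, three on a shared core have been read in an ADME assay on HepG2 cells (Homo sapiens) for cytotoxicity, with a stated time of 72 h; a lower number here means that less compound is needed, a higher number that more compound is needed for the effect. Compound 1 `Cc1cc(NC(=O)Nc2ccc(C(F)(F)F)cc2)c2ccccc2n1` gives 23000 nM. Compound 2 `Cc1cc(NC(=O)Nc2ccc(OC(F)(F)F)cc2)c2ccccc2n1` gives 15000 nM. Going by the values given here, the one measured step between them, a 1.5-fold lower number from compound 1 to compound 2 (0.19 log units; within the scatter), comes with trifluoromethoxy in place of trifluoromethyl on an aromatic carbon. Compound 3 `Cc1cc(NC(=O)Nc2cccnc2)c2ccccc2n1` gives > 25000 nM, and this is a limit of the assay, not a number.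

Compound 4 `Cc1cc(NC(=O)Nc2ccc(N)cc2)c2ccccc2n1` has not yet been measured in this assay. It carries 4-aminophenyl in place of pyridin-3-yl on an amide-type nitrogen. Among the compounds with values here, no measured step makes this exchange, so the step of a 1.5-fold lower number from compound 1 to compound 2 (0.19 log units; within the scatter) bears on it only indirectly, as a single swap on a carbon-only aromatic ring that stayed within the scatter. Compound 4 shares a ring of that kind with compound 1 at 23000 nM and compound 2 at 15000 nM. A modest shift towards a lower number than the limit of compound 3 is therefore expected, though a reading at the limit would not surprise. The expected step is an at least 1.3-fold lower number from compound 3 to compound 4 (0.14 log units; that floor lies within the scatter). For compound 4 the estimate is 18000 nM, with an expected range from 8000 nM to 30000 nM.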

Compound 4, half-maximal effective concentration: > 25000 nM
Compound 4: a limit, no number; the forecaster's own chance of this, stated with the estimate: 35%; middle value at least 1.3-fold (0.14 log units) away from the limit.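

In this assay the reading of compound 4 is a limit and not a number, and it is the same limit that compound 3 reached: the limit of > 25000 nM in this assay, at which 2 of the 4 values shown sit. Against the two compounds with a number, amino in place of trifluoromethoxy on an aromatic carbon gives an at least 1.6-fold higher number from compound 2 to compound 4 (0.22 log units; that floor lies within the scatter), while amino in place of trifluoromethyl gives an at least 1.0-fold higher number from compound 1 to compound 4 (0.03 log units; that floor lies within the scatter), so neither step shows a change beyond the scatter, though the true size of each remains hidden behind the limit. What compound 4 adds is that a carbon-only aromatic ring on the amide-type nitrogen does not by itself bring a reading inside the range of the assay, and the step between 4-aminophenyl and pyridin-3-yl cannot be read, since both ends of it are limits.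

As far as these compounds go, how far compound 3 and compound 4 lie beyond the limit, and whether they differ from each other at all, stays open. Also open, from the compounds shown here alone, is how a hydroxyl group or a carboxylic acid would read on the same aromatic carbon that carries the amino group in compound 4.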